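This account rests on a few compounds, and the source may have more. Where it says the series, first, only, none or still open, it means among the compounds named here.

Compound 1 `O=C(Nc1cc(-c2ccccn2)n[nH]1)N1CCC(Oc2ccccc2)CC1` in an ADME assay on liver (Mesocricetus auratus) for metabolic stability, using microsomes; on this read-out higher numbers stand for fast clearance and lower numbers for slow clearance: 98.5 mL.min-1.g-1.
Compound 2 `O=C(NCc1ccccc1)Nc1[nH]nc(-c2ccccn2)c1Cl` in this same assay: > 400 mL.min-1.g-1, which is a limit of the assay rather than a number.

Within the data shown here, compound 1 therefore holds the only numerical value here; the other result, for compound 2, is the limit of > 400 mL.min-1.g-1 in this assay, at which 1 of the 2 values shown sits. Compound 3 `O=C(Nc1cc(-c2ccccn2)n[nH]1)N1CCC(c2ccc(F)cc2)CC1` differs from compound 1 by 4-fluorophenyl in place of phenoxy on a saturated ring carbon. Among the measured compounds shown here, no step between two measured compounds is available to guide the size of this change, so only a modest shift, if any beyond the usual scatter, is expected, leaning toward slower clearance. For compound 3 the estimated value in this assay is 80 mL.min-1.g-1, within 35 mL.min-1.g-1 to 200 mL.min-1.g-1. This expectation amounts to a 1.2-fold lower number from compound 1 to compound 3 (0.09 log units; within the scatter).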

Compound 3, intrinsic clearance in microsomes: 272 mL.min-1.g-1
Compound 3: middle estimate off by 3.4-fold (0.53 log units), on the low side; the whole stated range lies below it.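

In this assay, the step of a 2.8-fold higher number from compound 1 to compound 3 (0.44 log units; beyond the scatter) shows that the group on this saturated ring carbon can affect clearance, even though phenoxy and 4-fluorophenyl have the same count of heavy atoms. The change goes toward faster clearance, not the slower clearance seen as likelier before. Nothing among the results shown accounts for this rise. As far as these compounds go, compound 3 loses the oxygen of phenoxy and gains the fluorine in one change, so their separate shares remain open. From the compounds shown here alone, how a plain phenyl or an amine on this carbon would compare is also open.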